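The source may hold more compounds than are shown below. What is called first, only, known or untested is meant among the compounds shown, and "the series" means these compounds.

Within the data shown here, in a functional assay on B16 cells (Mus musculus), read by spectrophotometry, with a stated time of 3 days (on this read-out lower numbers stand for stronger inhibition and higher numbers for weaker inhibition), compound 1 `CNC(=S)N/N=C/c1cccc2ccccc12` gives 2000 nM and compound 2 `S=C(N/N=C/c1cccc2ccccc12)Nc1ccc(Cl)cc1` gives 1900 nM while compound 3 `COc1ccc(NC(=S)N/N=C/c2cccc3ccccc23)cc1` gives 860 nM as the lowest of the three numbers so far. Still unmeasured is compound 4 `Cc1ccccc1NC(=S)N/N=C/c1cccc2ccccc12` with 2-methylphenyl in place of 4-methoxyphenyl on an amide-type nitrogen as its difference from compound 3, that is, 2-methylphenyl in place of 4-methoxyphenyl on an amide-type nitrogen. Among the measured compounds shown here, three measured steps bear on this change. The 4-chlorophenyl step is a 1.1-fold lower number from compound 1 to compound 2 (0.02 log units; within the scatter) and shows no real shift, whereas the 4-methoxyphenyl steps are a 2.3-fold lower number from compound 1 to compound 3 (0.37 log units; beyond the scatter) and a 2.2-fold lower number from compound 2 to compound 3 (0.34 log units; beyond the scatter) and both remain modest. For the measured compounds named here, no measured compound carries 2-methylphenyl, so this group has no direct precedent. With 4-methoxyphenyl gone, the number for compound 4 is expected to return toward the level of the other two, taking a 2.2-fold lower number from compound 2 to compound 3 (0.34 log units; beyond the scatter) in reverse as the nearest guide. The expected change is a 1.9-fold higher number from compound 3 to compound 4 (0.27 log units; within the scatter) in this assay as a modest step toward weaker inhibition. Compound 4 is estimated at 1600 nM within a range of 750 nM to 3400 nM for now.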

Compound 4, half-maximal inhibitory concentration: 490 nM
For compound 4 the middle estimate is 3.3-fold (0.51 log units) above the measured one; measured number below the stated range.
By their numbers in this assay, from the lowest: compounds 4 and 3 (each within the scatter of the next); then compounds 2 and 1 (each within the scatter of the next).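

Placing 2-methylphenyl for 4-methoxyphenyl on the amide-type nitrogen gives a 1.8-fold lower number from compound 3 to compound 4 (0.24 log units; within the scatter) in this assay and so stays within the scatter, which means the oxygen of 4-methoxyphenyl is not needed to hold the number at this level. Against the other two groups, the change is a 3.9-fold lower number from compound 2 to compound 4 (0.59 log units; beyond the scatter) for 2-methylphenyl in place of 4-chlorophenyl and a 4.1-fold lower number from compound 1 to compound 4 (0.61 log units; beyond the scatter) for 2-methylphenyl in place of methyl, both modest steps. An aromatic ring at this nitrogen does not alone lower the number, as compound 2 goes against that reading with a 1.1-fold lower number from compound 1 to compound 2 (0.02 log units; within the scatter) and no real shift.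

As far as these compounds go, how 4-methylphenyl or a longer chain such as butyl would read at this nitrogen remains open. The measurements shown offer no explanation for these differences.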